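Ring change on the ester-bearing substituent of compound 2

This account rests on a few compounds, and the source may have more. Where it says the series, first, only, none or still open, it means among the compounds named here.

For the measured compounds named here, compound 2 `COC(=O)C1=C(c2ccc(CNc3nccc(C)c3NC(=O)CC#N)cc2)CCC1` is, among the two compounds tested so far, the one with the higher number: in an assay on isolated protein for binding affinity to B1 bradykinin receptor (Homo sapiens) (on this read-out lower numbers stand for stronger inhibition and higher numbers for weaker inhibition), compound 2 gives 126 nM. Its closest measured relative is compound 1 `COC(=O)C1=C(c2ccc(CNc3nccc(C)c3NC(=O)CC#N)cc2)CCCC1`, which in this assay gives 35 nM. Going by the values given here, the only measured step is a 3.6-fold higher number from compound 1 to compound 2 (0.56 log units; beyond the scatter), which shows that swapping the six-membered carbon ring for a five-membered one weakened binding by a modest margin. Compound 3 `COC(=O)c1ccccc1-c1ccc(CNc2nccc(C)c2NC(=O)CC#N)cc1` is now considered; its change from compound 2 is 2-(methoxycarbonyl)phenyl in place of 2-(methoxycarbonyl)cyclopent-1-en-1-yl on an aromatic carbon. Among the compounds with values here, this returns to a six-membered ring at the same position, now an aromatic one, and the single measured step is the only guide. A modest improvement is therefore expected, with a 2.5-fold lower number from compound 2 to compound 3 (0.40 log units; beyond the scatter), though the aromatic ring is new ground and the range is kept wide. For compound 3 the estimate in this assay is 50 nM, within 15 nM to 160 nM.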

Compound 3, inhibition constant: 11 nM
Compound 3: middle estimate off by 4.5-fold (0.66 log units), on the high side, outside the stated range (below it).
By their numbers in this assay, from the lowest: compound 3; then compound 1; then compound 2.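

At this position, on an aromatic carbon para to a large group, the 2-(methoxycarbonyl)phenyl group gives the lowest number of the three in this assay, with an 11-fold lower number from compound 2 to compound 3 (1.06 log units; beyond the scatter) and a 3.2-fold lower number from compound 1 to compound 3 (0.50 log units; beyond the scatter). Ring size alone therefore does not settle the result, since compound 1 and compound 3 both carry a six-membered ring and still differ beyond the scatter, the aromatic ring giving the lower number. Nothing available here gives a reason for this gain.

As far as these compounds go, all three compounds carry the same methyl ester, so its own contribution remains open, and a carboxylic acid or a primary amide in its place would be a separate question. Also open, from the compounds shown here alone, is how a pyridine ring would compare with the phenyl ring in compound 3.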